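A few compounds are considered here, and "the series" means these few. Any claim that something is new, unique, unknown or untested is made for them only; others in the source may bear on it.

Of the compounds shown here, three have so far been measured in an assay on isolated protein for displacement of a labelled ligand from metabotropic glutamate receptor 5 (Homo sapiens), with a stated time of 60 min, tested at 1 uM; on this read-out lower numbers stand for less inhibition and higher numbers for more inhibition at the one concentration tested (going by the name of the read-out). Compound 1 `Cc1ccc(S(=O)(=O)c2cnc3ccc(Cl)cc3c2N2CCC(C)CC2)cc1` gives 95%, compound 3 `COc1ccc2ncc(S(=O)(=O)c3cccc(C#N)c3)c(N3CCC(C)CC3)c2c1` gives 90%, and compound 2 `CC1CCN(c2c(S(=O)(=O)c3cccc(F)c3)cnc3ccc(F)cc23)CC1` gives 76%, the lowest of the three, with compound 3 standing beyond the scatter above it and compound 1 further above still. Compound 4 `Cc1ccc(S(=O)(=O)c2cnc3ccc(F)cc3c2N2CCC(C)CC2)cc1C` has not yet been measured in this assay. It differs from compound 2 in one place: 3,4-dimethylphenyl in place of 3-fluorophenyl on a sulfonyl sulfur. Given that compound 1 reaches 95% on a closely related frame, the step is expected to run upward and beyond the scatter, estimated at a number 12 percentage points higher from compound 2 to compound 4 (beyond the scatter). In this assay compound 4 is therefore expected to give about 88%, within a range from 72% to 97%.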

Compound 4, a percentage reported as inhibition, at one concentration (the size of the read-out at that concentration, not a potency): 92%
For compound 4 the middle estimate is 4 percentage points below the measured one, within the range that was stated.
By their numbers in this assay, from the lowest: compound 2; then compounds 3, 4 and 1 (each within the scatter of the next).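

In this assay, for the compounds shown here, the change to 3,4-dimethylphenyl in place of 3-fluorophenyl on a sulfonyl sulfur gives a number 16 percentage points higher from compound 2 to compound 4 (beyond the scatter) and is the first comparison here in which only one place differs. It shows that the aromatic group at this place can move the read-out beyond the scatter, with the shared core and the rest of the compound unchanged. No measurement at hand gives a reason for this step.

The compounds shown leave open how an amine or a carboxylic acid on this phenyl ring would fare. A single tested concentration also leaves the potency of compound 4 open.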